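The compounds below may be only part of what the source reports. "The series", "measured", "known", "first", "only" and "open" are said of these compounds alone.

Measured so far in a functional assay on A549 cells (Homo sapiens) for inhibition, read by sulforhodamine B assay, with a stated time of 48 h; on this read-out lower numbers stand for stronger inhibition of growth and higher numbers for weaker inhibition of growth:
compound 1 `COC(=O)[C@@]1(C)CCC=C2[C@@H]1CC[C@@H](C)[C@]2(C)Cc1c[nH]c2ccc(Br)cc12` gives 15000 nM
compound 2 `COC(=O)[C@@]1(C)CCC=C2[C@@H]1CC[C@@H](C)[C@]2(C)Cc1c[nH]c2ccc(Cl)cc12` gives 16000 nM
compound 3 `COC(=O)[C@@]1(C)CC[C@@H]2C3=C1CC[C@@H](C)[C@]3(C)C[C@@H]1c3cccc(Br)c3N[C@H]21` gives 42000 nM

Compound 1 and compound 2 share one core; the change between them is chloro in place of bromo on an aromatic carbon, and the step is a 1.1-fold higher number from compound 1 to compound 2 (0.03 log units; within the scatter). Compound 3 is built on a different core; the difference between the two cores is not broken down here. Compound 3 gives the highest number of the three, beyond the scatter from both compound 1 and compound 2.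

Compound 4 `COC(=O)[C@@]1(C)CC[C@@H]2C3=C1CC[C@@H](C)[C@]3(C)C[C@@H]1c3cccc(Cl)c3N[C@H]21` stands to compound 3 as compound 2 stands to compound 1: the change is chloro in place of bromo on an aromatic carbon. It is the same kind of change, not the same one: in compound 1 the aromatic carbon sits in a fused system of two rings, meta and para to a fused ring, whereas in compound 3 it sits in a fused system of five rings, ortho and meta to a fused ring. Because a 1.1-fold higher number from compound 1 to compound 2 (0.03 log units; within the scatter) lies within the scatter, the step of a 1.1-fold higher number from compound 3 to compound 4 (0.03 log units; within the scatter) is expected to be small as well. Compound 4 is expected at 45000 nM, between 22000 nM and 90000 nM.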

Compound 4, concentration for 50% growth inhibition: 54000 nM
Beside the measured number, compound 4's estimate is 1.2-fold (0.08 log units) below it; measured number inside the range.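

In this assay, chloro in place of bromo on an aromatic carbon gives a small step on the core of compound 3: a 1.3-fold higher number from compound 3 to compound 4 (0.11 log units; within the scatter). The exchange behaves alike on the two cores: the same change on two cores in this assay, a 1.1-fold higher number (0.03 log units; within the scatter) from compound 1 to compound 2 and a 1.3-fold higher number (0.11 log units; within the scatter) from compound 3 to compound 4, 1.2-fold (0.08 log units) apart, within the scatter of two such steps. This shows that this one exchange of halogens carries over between these two cores, but it does not show that any other change would carry over, and it does not account for the difference between the cores.

Other groups on this aromatic carbon, such as an amine or a methoxy group, remain open. As far as these compounds go, the methyl ester is common to all four compounds, so the effect of a carboxylic acid or an amide in its place also remains open.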